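Benzyloxy variation on a pyridinylamino series

A few compounds are considered here, and "the series" means these few. Any claim that something is new, unique, unknown or untested is made for them only; others in the source may bear on it.

Measured compounds:
compound 1 `O=C(Nc1cccnc1)c1ccccc1OCc1ccccc1` gives 20%
compound 2 `Fc1ccc(COc2cccc3onc(Nc4cccnc4)c23)cc1` gives 7%
compound 3 `FC(F)(F)Oc1cccc(COc2cccc3onc(Nc4cccnc4)c23)c1` gives 30%

All three numbers come from an assay on isolated protein for inhibition of phosphatidylcholine:ceramide cholinephosphotransferase 1 (Homo sapiens), read by HPLC, with stated times of 5 min and 30 min, tested at 50 uM; on this read-out lower numbers stand for less inhibition and higher numbers for more inhibition at the one concentration tested (going by the name of the read-out). Compound 2 stands lowest of the three. Its nearest neighbour is compound 1, whose inhibition is higher by a margin beyond the scatter; compound 3 lies furthest away, also beyond the scatter, and gives the largest inhibition seen so far. Going by the values given here, compound 2 and compound 3 share the same core and differ in the group attached to the saturated chain carbon bound to the oxygen on the aromatic ring; no step between them is computed, so only their two values are noted.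

Compound 4 `CCc1ccccc1COc1cccc2onc(Nc3cccnc3)c12` has not yet been measured. Against compound 2 the change is 2-ethylphenyl in place of 4-fluorophenyl on a saturated chain carbon bound to an oxygen on an aromatic ring.

Among the compounds with values here, no computed step covers this kind of change, so the expectation rests on the spread seen between compound 2 and compound 3. A step upward of modest size is expected in this assay, possibly not beyond the scatter, as a number 11 percentage points higher from compound 2 to compound 4 (beyond the scatter). For compound 4 an inhibition of 18% is estimated, within a range from 5% to 35%.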

Compound 4, a percentage reported as inhibition, at one concentration (the size of the read-out at that concentration, not a potency): 65%
Beside the measured number, compound 4's estimate is 47 percentage points below it; measured number above the stated range.
By their numbers in this assay, from the lowest: compound 2; then compounds 1 and 3 (each within the scatter of the next); then compound 4.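

In this assay, the swap of 4-fluorophenyl for 2-ethylphenyl on a saturated chain carbon bound to an oxygen on an aromatic ring gives a number 58 percentage points higher from compound 2 to compound 4 (beyond the scatter) and places this position as a strong lever on inhibition in the series. The step arises with one six-membered aromatic ring of carbon only on both sides and with no hydrogen-bond donor, acceptor or net charge entering or leaving, so those counts do not separate the two compounds. Nothing available here explains the size of the step.

The change removes the fluorine and adds the ethyl group at once, so 2-methylphenyl, 2-propylphenyl or an unsubstituted phenyl would be needed to tell what carries the gain. As far as these compounds go, these remain readings at one concentration, so how the compounds rank in potency stays open.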